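Longer alkyne chains and tolerance in HEL cells

The compounds below may be only part of what the source reports. "The series", "measured", "known", "first", "only" and "open" are said of these compounds alone.

Four compounds share one core, a bicyclic base joined to a sugar, and differ only in the length of a saturated chain that hangs from a triple bond. Compound 1 is `CCCCC#Cc1cc2cn([C@@H]3O[C@H](CO)[C@@H](O)[C@@H]3O)c(=O)nc2o1`, compound 2 is `CCCCCCC#Cc1cc2cn([C@@H]3O[C@H](CO)[C@@H](O)[C@@H]3O)c(=O)nc2o1`, compound 3 is `CCCCCCCCC#Cc1cc2cn([C@@H]3O[C@H](CO)[C@@H](O)[C@H]3O)c(=O)nc2o1`, and compound 4, not yet measured, is `CCCCCCCCCCC#Cc1cc2cn([C@@H]3O[C@H](CO)[C@@H](O)[C@H]3O)c(=O)nc2o1`.

They were tested in a functional assay on HEL cells (Homo sapiens) for cytotoxicity; a higher number here means that more compound is tolerated, a lower number that less compound is tolerated. For compound 1 the reading is > 144000 nM, which is a limit of the assay and not a number; this is the limit of > 144000 nM in this assay, at which 1 of the 3 values shown sits. Compound 2 gives 133000 nM in this assay, and compound 3 gives 49000 nM.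

Compound 2 differs from compound 1 by ethyl in place of hydrogen on a saturated chain carbon, four bonds along the chain from a triple-bonded carbon, and the step is an at least 1.0-fold lower number from compound 1 to compound 2 (0.03 log units; that floor lies within the scatter). Compound 4 differs from compound 3 by ethyl in place of hydrogen on a saturated chain carbon, eight bonds along the chain from a triple-bonded carbon; this is the same kind of change, made on a chain carbon eight bonds along rather than four bonds along from the triple-bonded carbon. The difference between the core of compound 1 and the core of compound 3 is not broken down here.

Because compound 3 gives 49000 nM while compound 2 gives 133000 nM, the longer chain went with a lower tolerated concentration, and the step to compound 4 is expected to continue downward. The expected step is estimated as a 2.2-fold lower number from compound 3 to compound 4 (0.35 log units; beyond the scatter). Compound 4 is therefore expected to give about 22000 nM, with a likely range from 8000 nM to 60000 nM.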

Compound 4, minimum cytotoxic concentration: 12000 nM
Compound 4: the middle estimate sits 1.8-fold (0.26 log units) above what was measured; the measured number falls inside the stated range.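

On the core of compound 3, ethyl in place of hydrogen on a saturated chain carbon, eight bonds along the chain from a triple-bonded carbon, gives a 4.1-fold lower number from compound 3 to compound 4 (0.61 log units; beyond the scatter) in this assay, so here the longer chain goes with less compound being tolerated. Set beside the same kind of change on the core of compound 1, this result does not show whether the change carries over from one core to the other with the same size, and it does not show that the two cores respond differently: the same change on two cores in this assay, an at least 1.0-fold lower number (0.03 log units; that floor lies within the scatter) from compound 1 to compound 2 and a 4.1-fold lower number (0.61 log units; beyond the scatter) from compound 3 to compound 4; the limit leaves it open whether they differ. The reading for compound 1 is a limit of the assay and not a number, which means the first step has only a floor and no true size: the limit of > 144000 nM in this assay, at which 1 of the 4 values shown sits.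

The two steps also sit at different places on the chain, four bonds along and eight bonds along from the triple-bonded carbon, so the compounds shown leave open how much of any gap belongs to the core and how much to the chain length. Also open, from the compounds shown here alone, is whether a still longer chain would lower the number further, and whether a chain ending in an amine or a carboxylic acid would follow the same course.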